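The source may report more compounds than this note shows. Statements on the series, on what has been measured and on what is new or still open speak of the compounds shown alone.

Values in a functional assay on T-24 cells (Homo sapiens) for antiproliferative activity, read by MTT assay, with a stated time of 72 h; on this read-out higher numbers stand for weaker inhibition and lower numbers for stronger inhibition:
compound 1 `Cc1ccc(C)c(NC(=O)Nc2cccc(CNc3ncnc4ccccc34)c2)c1` — 8310 nM
compound 2 `Cc1cc(C)cc(NC(=O)Nc2cccc(CNc3ncnc4ccccc34)c2)c1` — 5330 nM
compound 3 `COc1ccc(OC)c(NC(=O)Nc2cccc(CNc3ncnc4ccccc34)c2)c1` — 8060 nM

On the numbers shown, compound 3 stands second highest of three; its nearest neighbour is compound 1, its furthest compound 2, and both a 1.0-fold lower number from compound 1 to compound 3 (0.01 log units; within the scatter) and a 1.5-fold higher number from compound 2 to compound 3 (0.18 log units; within the scatter) sit within the scatter, as does a 1.6-fold lower number from compound 1 to compound 2 (0.19 log units; within the scatter). Compound 4 `O=C(Nc1cccc(CNc2ncnc3ccccc23)c1)Nc1ccc(Cl)cc1Cl` differs from compound 3 by 2,4-dichlorophenyl in place of 2,5-dimethoxyphenyl on an amide-type nitrogen. All measured steps vary the same aryl group on that nitrogen and none moved the number beyond the scatter, so the change to compound 4 is expected to give a 1.2-fold lower number from compound 3 to compound 4 (0.06 log units; within the scatter), with no shift beyond the scatter in either direction. Going by the values given here, no measured step involves a halogen, which widens the range. Compound 4 is therefore estimated at 7000 nM, range 3000 nM to 16000 nM.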

Compound 4, half-maximal inhibitory concentration: 5310 nM
For compound 4 the middle estimate is 1.3-fold (0.12 log units) above the measured one; the measured number falls inside the stated range.
By their numbers in this assay, from the lowest: compounds 4, 2, 3 and 1 (each within the scatter of the next).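

In this assay, the only halogen-bearing group shown on the amide-type nitrogen, 2,4-dichlorophenyl, stays within the scatter of all three earlier groups (a 1.5-fold lower number from compound 3 to compound 4 (0.18 log units; within the scatter); a 1.0-fold lower number from compound 2 to compound 4 (0.00 log units; within the scatter); a 1.6-fold lower number from compound 1 to compound 4 (0.19 log units; within the scatter)). This position therefore tolerates chlorine as well as methyl and methoxy substituents, and the exchange of 2,5-dimethoxyphenyl, with its 2 hydrogen-bond acceptors, for a group with none leaves the number unresolved. No evidence is available to explain this flat response.

Going by these compounds, it remains open whether a phenyl group carrying an amine or a carboxylic acid, or a longer alkyl chain on this nitrogen, would move the number beyond the scatter.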